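The source may hold more compounds than are shown below. What is called first, only, known or untested is meant among the compounds shown, and "the series" means these compounds.

Measured so far in an assay on CHO cells for antagonist activity at transient receptor potential cation channel subfamily V member 1 (Homo sapiens), read by FLIPR; a higher number here means a weaker inhibitor, a lower number a stronger inhibitor:
compound 1 `CC(C(=O)NCc1ccc(C(F)(F)F)cc1N1CCCCCC1)c1ccc(NS(C)(=O)=O)c(F)c1` gives 1.6 nM
compound 2 `CC(C(=O)NCc1ccc(C(F)(F)F)cc1OC1CCCCC1)c1ccc(NS(C)(=O)=O)c(F)c1` gives 0.7 nM
compound 3 `CC(C)CCSc1cc(C(F)(F)F)ccc1CNC(=O)C(C)c1ccc(NS(C)(=O)=O)c(F)c1` gives 1.4 nM

Compound 3 holds the second highest of the three numbers, but its gaps to both other compounds are within the scatter: a 1.1-fold lower number from compound 1 to compound 3 (0.06 log units; within the scatter) and a 2.0-fold higher number from compound 2 to compound 3 (0.30 log units; within the scatter). Among the measured compounds shown here, the one step that clears the scatter is a 2.3-fold lower number from compound 1 to compound 2 (0.36 log units; beyond the scatter), which is modest.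

Compound 4 `CC(C(=O)NCc1ccc(C(F)(F)F)cc1SC1CCCCC1)c1ccc(NS(C)(=O)=O)c(F)c1` is not yet measured. Its change from compound 3 is cyclohexyl in place of isopentyl on a sulfur. The step that bears on it most directly is a 2.0-fold higher number from compound 2 to compound 3 (0.30 log units; within the scatter), where cyclohexyloxy gave way to isopentylsulfanyl and the number moved within the scatter; compound 4 reverses the cyclohexyl-to-isopentyl part of that exchange while keeping the sulfur. The step from azepan-1-yl, a 1.1-fold lower number from compound 1 to compound 3 (0.06 log units; within the scatter), also stayed within the scatter. The expected step is therefore estimated as a 1.4-fold lower number from compound 3 to compound 4 (0.15 log units; within the scatter), a somewhat lower number that stays within the scatter. Compound 4 is estimated at 1 nM, within a range of 0.4 nM to 2.5 nM.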

Compound 4, inhibition constant: 0.5 nM
Compound 4: middle estimate off by 2.0-fold (0.30 log units), on the high side; measured number inside the range.
By their numbers in this assay, from the lowest: compounds 4, 2, 3 and 1 (each within the scatter of the next, the first and the last beyond it).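

With the sulfur held constant in this assay, cyclohexyl in place of isopentyl gives a step that clears the scatter (a 2.8-fold lower number from compound 3 to compound 4 (0.45 log units; beyond the scatter)), which isolates the group on the sulfur in a way the earlier cross-atom exchanges could not. With the cyclohexyl ring kept, cyclohexylsulfanyl in place of cyclohexyloxy stays within the scatter (a 1.4-fold lower number from compound 2 to compound 4 (0.15 log units; within the scatter)), so this pair does not separate sulfur from oxygen at this position. Cyclohexylsulfanyl also stands clear of azepan-1-yl (a 3.2-fold lower number from compound 1 to compound 4 (0.51 log units; beyond the scatter)), and no measurement on hand accounts for any of these steps.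

Going by these compounds, it remains open whether the step on the sulfur follows the ring itself or the change of chain shape, which a cyclopentyl group or a straight hexyl chain there would test. Also open, on these data alone, is how a hydroxyl or an amine on the cyclohexyl ring would read in this assay here.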